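This account rests on a few compounds, and the source may have more. Where it says the series, first, only, none or still open, it means among the compounds named here.

Measured in an ADME assay on MT4 cells (Homo sapiens) for cytotoxicity, read by MTT assay (a higher number here means that more compound is tolerated, a lower number that less compound is tolerated), so far:
compound 1 `Cc1c(Cc2c(F)cccc2F)nc(SC(C)C)[nH]c1=O` gives > 77000 nM (a limit)
compound 2 `CC(C)c1c(Cc2c(F)cccc2Cl)nc(SCC(=O)c2ccccc2)[nH]c1=O` gives > 12000 nM (a limit)
compound 3 `Cc1c(Cc2c(F)cccc2F)nc(SCC(=O)c2ccccc2)[nH]c1=O` gives 65000 nM

Compound 3 holds the only number among these values, and the other two are limits. The next compound to be read is compound 4 `CC(C)c1c(Cc2c(F)cccc2F)nc(SCC(=O)c2ccccc2)[nH]c1=O`, which has isopropyl in place of methyl on an aromatic carbon.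

Among the measured compounds shown here, no measured step changes this aromatic carbon. For the measured compounds named here, the one step available, an at least 1.1-fold lower number from compound 1 to compound 3 (0.07 log units; that floor lies within the scatter), concerns the group on sulfur, and its floor lies within the scatter, so it gives only weak guidance. Compound 2 is the nearest reference, with isopropyl on the same aromatic carbon, benzoylmethyl on sulfur and a different benzyl group. Its reading is a limit, as the limit of > 12000 nM in this assay, at which 1 of the 3 values shown sits, shows, and so gives no size for the change. Compound 1 also stands at a limit, as the limit of > 77000 nM in this assay, at which 1 of the 3 values shown sits, shows.

The expectation therefore rests mainly on compound 3 at 65000 nM, with only a modest move towards a lower number in this assay. The expected step is a 2.2-fold lower number from compound 3 to compound 4 (0.34 log units; beyond the scatter), though compound 4 may also read as a limit. For compound 4 the estimated value is 30000 nM, with an expected range from 10000 nM to 80000 nM.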

Compound 4, half-maximal cytotoxic concentration: > 60000 nM
Compound 4 gave a limit, no number; the forecaster's own chance of this, stated with the estimate: 45%; at least 2.0-fold (0.30 log units) between middle value and limit.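

In this assay compound 4 gives > 60000 nM, which is a limit and not a number. No new step can be read from it: the comparisons of compound 4 with compound 3 and with compound 2 both remain without a size. The compounds shown leave open how far isopropyl in place of methyl on an aromatic carbon, or fluoro in place of chloro on an aromatic carbon, moves the reading in this assay.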